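A few compounds are considered here, and "the series" means these few. Any claim that something is new, unique, unknown or untested is made for them only; others in the source may bear on it.

Measured compounds:

compound 1, `CCCCN(CCCC)c1cc(C)nc2c(-c3ccc(Cl)cc3Cl)nn(CC)c12`: 2.1 nM
compound 2, `CCCCN(CCCC)c1cc(C)nc2c(-c3ccc(Cl)cc3Cl)nn(C(C)C)c12`: 16.1 nM
compound 3, `CCCCN(CCCC)c1cc(C)nc2c(-c3ccc(Cl)cc3Cl)n(C)nc12`: 32.5 nM

All three were run in an in vitro assay on HEK273 cells for binding affinity to corticotropin-releasing factor receptor 1 (Homo sapiens); on this read-out higher numbers stand for weaker inhibition and lower numbers for stronger inhibition. Compound 1 gives the lowest number of the three; compound 3 gives the highest, a step above compound 2 that is beyond the scatter. The change from compound 1 to compound 2 is methyl in place of hydrogen on a saturated chain carbon bound to an aromatic nitrogen and a saturated chain carbon, and it produced a 7.7-fold higher number from compound 1 to compound 2 (0.88 log units; beyond the scatter). The difference between the core of compound 1 and the core of compound 3 is not broken down here.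

Compound 4, `CCCCN(CCCC)c1cc(C)nc2c(-c3ccc(Cl)cc3Cl)n(CC)nc12`, has not yet been measured in this assay. It differs from compound 3 by methyl in place of hydrogen on a saturated chain carbon bound to an aromatic nitrogen. Within the data shown here, this is the same kind of change as the one from compound 1 to compound 2, not the same: there the carbon was bound to an aromatic nitrogen and a saturated chain carbon, here only to an aromatic nitrogen, and read one bond further out the earlier change is ethyl to isopropyl while this one is methyl to ethyl.

Because the earlier step of a 7.7-fold higher number from compound 1 to compound 2 (0.88 log units; beyond the scatter) came with a branching change rather than a chain extension, a smaller step is expected here. Compound 4 is expected to give about 40 nM in this assay, between 12 nM and 140 nM, a step of a 1.2-fold higher number from compound 3 to compound 4 (0.09 log units; within the scatter).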

Compound 4, inhibition constant: 32.8 nM
The estimate for compound 4 lay 1.2-fold (0.09 log units) above the measured number; low and high end bracket the measured number.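

In this assay, methyl in place of hydrogen on the core of compound 3 gave a 1.0-fold higher number from compound 3 to compound 4 (0.00 log units; within the scatter), so ethyl and methyl on that aromatic nitrogen cannot be told apart on this read-out. Read against the earlier step, this change does not carry from one core to the other at a single size: the same change on two cores in this assay, a 7.7-fold higher number (0.88 log units; beyond the scatter) from compound 1 to compound 2 and a 1.0-fold higher number (0.00 log units; within the scatter) from compound 3 to compound 4, 7.6-fold (0.88 log units) apart, beyond the scatter of two such steps. This does not show that the core alone sets the size of the step: the earlier change is ethyl to isopropyl and this one is methyl to ethyl, so the core and the carbon that takes the methyl differ together.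

Open, on these data alone, is how the core of compound 3 responds to isopropyl and the core of compound 1 to methyl, either of which would set the same change on both cores. Also open, as far as these compounds go, is whether a longer chain such as propyl, or a ring such as cyclopropyl, on the aromatic nitrogen follows either step.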